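Methoxy removal on a trimethoxyphenyl chalcone pyrazole series

A few compounds are considered here, and "the series" means these few. Any claim that something is new, unique, unknown or untested is made for them only; others in the source may bear on it.

Measured compounds:
compound 1, `COc1cc(-c2cc(/C=C/C(=O)c3ccc(N)cc3)[nH]n2)cc(OC)c1OC`: -20%
compound 2, `COc1ccc(-c2cc(/C=C/C(=O)c3ccc(N)cc3)[nH]n2)cc1OC`: -18%
compound 3, `COc1cc(C(=O)/C=C/c2cc(-c3cc(OC)c(OC)c(OC)c3)n[nH]2)cc(OC)c1OC`: -89%

In a functional assay on SW-620 cells (Homo sapiens) for cytotoxicity, read by sulforhodamine B assay, with a stated time of 48 h, tested at 10 uM (on this read-out higher numbers stand for a weaker effect at the one concentration tested and lower numbers for a stronger effect), compound 1 gives -20% and compound 2 gives -18%; these two values stand within the scatter of each other. Compound 2 differs from compound 1 by hydrogen in place of methoxy on an aromatic carbon, and that change made a step of a number 2 percentage points higher from compound 1 to compound 2 (within the scatter). Compound 3 stands apart: in this assay compound 3 gives -89%, the lowest of the three numbers and beyond the scatter from compound 1 and from compound 2. The difference between the core of compound 3 and the core of compound 1 is not broken down here.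

Compound 4, `COc1ccc(-c2cc(/C=C/C(=O)c3cc(OC)c(OC)c(OC)c3)[nH]n2)cc1OC`, is not yet measured. Going by the values given here, it differs from compound 3 by hydrogen in place of methoxy on an aromatic carbon, the same change as the one from compound 1 to compound 2, made at a place described in the same words. Since that earlier step was a number 2 percentage points higher from compound 1 to compound 2 (within the scatter), the expected step from compound 3 to compound 4 in this assay is small, about a number 7 percentage points higher from compound 3 to compound 4 (within the scatter), resting only on that single precedent. For compound 4 the estimate in this assay is -82%, with a range from -96% to -50%.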

Compound 4, a percentage reported as activity, at one concentration (the size of the read-out at that concentration, not a potency): -43%
Compound 4: the middle estimate sits 39 percentage points below what was measured; measured number above the stated range.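

In this assay the replacement of methoxy by hydrogen made a step of a number 46 percentage points higher from compound 3 to compound 4 (beyond the scatter) on the core of compound 3. Set beside the earlier step, this shows that the change did not keep its size from one core to the other: the same change on two cores in this assay, a number 2 percentage points higher (within the scatter) from compound 1 to compound 2 and a number 46 percentage points higher (beyond the scatter) from compound 3 to compound 4, 44 percentage points apart, beyond the scatter of two such steps. These two pairs show only that, in this series, the size of the step found on one core cannot be assumed on the other; they give no general rule for further cores, and they do not tell which difference between the two cores goes with the larger step.

The compounds shown leave open whether the step would stay small or grow on a core carrying a hydroxy group or a carboxylic acid where compound 1 has its amine. They also leave open whether ethoxy or chlorine in place of the methoxy would give a step of similar size on either core.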